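Methoxy Placement on Piperazine Aryl Groups in a Cytotoxicity Series

The source may report more compounds than this note shows. Statements on the series, on what has been measured and on what is new or still open speak of the compounds shown alone.

Measured compounds:
Compound 1 `O=C(CN1CCN(c2ccccc2)CC1)N1CCN(c2nnc(-c3ccccc3)c(-c3ccccc3)n2)CC1`: in a functional assay on MCF7 cells (Homo sapiens) for cytotoxicity, read by MTT assay, with a stated time of 24 h (a higher number here means a weaker inhibitor, a lower number a stronger inhibitor), compound 1 gives > 963000 nM.
Compound 2 `COc1cccc(N2CCN(CC(=O)N3CCN(c4nnc(-c5ccccc5)c(-c5ccccc5)n4)CC3)CC2)c1`: in this assay compound 2 gives > 910000 nM.
Compound 3 `COc1ccc(-c2nnc(N3CCN(C(=O)CN4CCN(c5ccccc5)CC4)CC3)nc2-c2ccc(OC)cc2)cc1`: in this assay compound 3 gives > 863000 nM.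

The value of compound 1 is a limit of the assay, not a number: the limit of > 963000 nM in this assay, at which 1 of the 3 values shown sits. The value of compound 2 is likewise a limit: the limit of > 910000 nM in this assay, at which 1 of the 3 values shown sits. The value of compound 3 is also a limit: the limit of > 863000 nM in this assay, at which 1 of the 3 values shown sits. From compound 1 to compound 2 the change is methoxy in place of hydrogen on an aromatic carbon, and a step that the two limits leave unreadable from compound 1 to compound 2. The difference between the cores of compound 1 and compound 3 is not broken down here. Compound 4 `COc1ccc(-c2nnc(N3CCN(C(=O)CN4CCN(c5ccccc5OC)CC4)CC3)nc2-c2ccc(OC)cc2)cc1` arises from compound 3 by methoxy in place of hydrogen on an aromatic carbon. The two places are not the same, meta to a large group in one and ortho to a large group in the other, so this is the same kind of change, not the same. Because a step that the two limits leave unreadable from compound 1 to compound 2 gives no readable size, the expected step is a step that the limit leaves unreadable from compound 3 to compound 4 in this assay, most likely ending again at a limit. Compound 4 is expected to give 900000 nM, between 400000 nM and 2000000 nM, in this assay.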

Compound 4, half-maximal inhibitory concentration: > 821000 nM
Compound 4: no number, only a limit; the forecaster's own chance of this, stated with the estimate: 85%; the middle value lies beyond the limit too.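

Compound 3 and compound 4 both give only limits, not numbers, so the step between them cannot be read. The compounds shown leave open what size, if any, the change from phenyl to 2-methoxyphenyl has in this assay.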